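The source may hold more compounds than are shown below. What is called first, only, known or untested is meant among the compounds shown, and "the series" means these compounds.

Measured in an ADME assay on Vero cells (Chlorocebus sabaeus) for cytotoxicity, with a stated time of 5 days (a lower number here means a stronger inhibitor, a higher number a weaker inhibitor), with every entry a limit and not a number:
Compound 1 `COc1nc(NC2CC2)c2ncn([C@H]3C[C@H](N=[N+]=[N-])[C@@H](CO)O3)c2n1` gives > 100000 nM
Compound 2 `CC(C)(CO)Nc1nc(N)nc2c1ncn2[C@H]1C[C@H](N=[N+]=[N-])[C@@H](CO)O1` gives > 100000 nM
Compound 3 `COc1nc(F)nc2c1ncn2[C@H]1C[C@H](N=[N+]=[N-])[C@@H](CO)O1` gives > 100000 nM

Compound 2 stands at a limit (> 100000 nM) and has no number in this assay to set against the others. Compound 1 and compound 3 are limits as well, so the whole set comes down to one reading (the limit of > 100000 nM in this assay, at which 3 of the 3 values shown sit). None of the three can be ranked against another, and no two of them form a measured step.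

Compound 4 `C#CCNc1nc(N)nc2c1ncn2[C@H]1C[C@H](N=[N+]=[N-])[C@@H](CO)O1` has not yet been tested. Its difference from compound 2 is this: propargyl in place of 1-(hydroxymethyl)-1-methylethyl on a nitrogen on an aromatic ring so propargyl replaces 1-(hydroxymethyl)-1-methylethyl on a nitrogen on an aromatic ring, and (1-(hydroxymethyl)-1-methylethyl)amino becomes propargylamino.

For the measured compounds named here, no measured step speaks to this swap, so the expectation rests on compound 2, which is held at its limit (> 100000 nM), and on the shared reading of the set (the limit of > 100000 nM in this assay, at which 3 of the 3 values shown sit). No change beyond the scatter is expected in either direction, and the estimated move (a number no higher from compound 2 to compound 4 (the limit leaves the size open)) is correspondingly small. A report at the same limit is the most likely outcome. As a value, compound 4 is estimated at 100000 nM (expected range 40000 nM to 200000 nM).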

Compound 4, half-maximal inhibitory concentration: > 100000 nM
Compound 4 ended at the assay's limit; the forecaster's own chance of this, stated with the estimate: 85%; the middle value lies on the limit itself.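

In this assay compound 4 gives > 100000 nM as a limit of the assay. Compound 2 stands at the same limit, so no step can be read between compound 2 and compound 4. The compounds shown leave open how propargyl and 1-(hydroxymethyl)-1-methylethyl compare in this assay, since every entry shares one reading: the limit of > 100000 nM in this assay, at which 4 of the 4 values shown sit.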